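Furan carboxamide series: carboxy to hydroxymethyl on the chain

This account rests on a few compounds, and the source may have more. Where it says the series, first, only, none or still open, it means among the compounds named here.

Of the compounds shown here, three have been measured in a functional assay on HCT-116 cells (Homo sapiens) for antiproliferative activity, read by sulforhodamine B assay, with a stated time of 72 h; on this read-out higher numbers stand for weaker inhibition and lower numbers for stronger inhibition. Compound 1 `Cn1ncc(Cl)c1-c1cc(C(=O)N[C@H]2CNCC[C@@H]2c2ccc(C(F)(F)F)cc2)oc1Cl` gives 1050 nM. Compound 3 `CC(=O)OCC[C@@H]1C[C@@H](c2ccc(F)c(F)c2)[C@H](NC(=O)c2cc(-c3c(Cl)cnn3C)c(Cl)o2)CN1` gives 690 nM. Compound 2 `Cn1ncc(Cl)c1-c1cc(C(=O)N[C@@H]2CN[C@H](CC(=O)O)C[C@H]2c2ccc(Cl)c(Cl)c2)oc1Cl` gives 4020 nM, the highest number of the three and the weakest inhibition in this set, beyond the scatter from both compound 1 and compound 3. Among the measured compounds shown here, no single-change pair among the measured compounds exists, so no measured step is available to lean on.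

Compound 4 `Cn1ncc(Cl)c1-c1cc(C(=O)N[C@@H]2CN[C@H](CCO)C[C@H]2c2ccc(Cl)c(Cl)c2)oc1Cl` has not yet been measured. It differs from compound 2 by hydroxymethyl in place of carboxy on a saturated chain carbon bound to a saturated ring carbon. The change keeps one hydrogen-bond donor and one hydrogen-bond acceptor on the chain while removing the double bond and one oxygen.

For the measured compounds named here, the step from compound 2 to compound 4 is expected to lower the number, probably beyond the scatter, at a 3.4-fold lower number from compound 2 to compound 4 (0.53 log units; beyond the scatter), since the only other measured compound with a neutral chain, compound 3, gives 690 nM. Compound 4 is therefore estimated at 1200 nM, with a range from 400 nM to 3500 nM.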

Compound 4, half-maximal inhibitory concentration: 340 nM
Beside the measured number, compound 4's estimate is 3.5-fold (0.55 log units) above it; measured number below the stated range.
By their numbers in this assay, from the lowest: compound 4; then compounds 3 and 1 (each within the scatter of the next); then compound 2.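

In this assay, the series now has its first single-change step: a 12-fold lower number from compound 2 to compound 4 (1.07 log units; beyond the scatter), large and beyond the scatter, with hydroxymethyl in place of carboxy on a saturated chain carbon bound to a saturated ring carbon. Compound 2 differs from each earlier compound in more than one place, so its high number could not be tied to any single part of the structure; this step shows that the read-out is highly sensitive to the group at this chain end, with the rest of the structure held constant. No supporting measurement accompanies the step, so it stands as an observation without an assigned cause.

On these data alone, it stays open how an amine, a primary amide or a longer chain ending in hydroxyl would read at this place, and so how far the step reflects the loss of carboxy and how far the arrival of hydroxymethyl. The step also rests on one pair, which leaves open whether the same change would give a step of similar size alongside other aryl substituents, such as the trifluoromethyl of compound 1.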